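Shortening the Selenium Side Chain: Expected Gain in Potency

This account rests on a few compounds, and the source may have more. Where it says the series, first, only, none or still open, it means among the compounds named here.

Compound 1 `COc1ccc(N(C)c2nc(C)nc3ccccc23)cc1C(=O)OCC[Se]C#N`: 1480 nM
Compound 2 `COc1ccc(N(C)c2nc(C)nc3ccccc23)cc1[Se]C`: 10 nM
Compound 3 `COc1ccc(N(C)c2nc(C)nc3ccccc23)cc1C(=O)OCCCC[Se]C#N`: 554 nM

These numbers come from a functional assay on MDA-MB-231 cells (Homo sapiens) for inhibition, read by MTT assay, with a stated time of 48 h; a higher number here means a weaker inhibitor, a lower number a stronger inhibitor. Compound 3 stands second highest of the three, below compound 1 and well above compound 2. Compound 4 `COc1ccc(N(C)c2nc(C)nc3ccccc23)cc1C[Se]C#N` differs from compound 3 by a group of 4 heavy atoms (2 carbon, 1 nitrogen, 1 selenium; no ring) in place of a group of 10 heavy atoms (6 carbon, 1 nitrogen, 2 oxygen, 1 selenium; no ring), on an aromatic carbon. Among the compounds with values here, two measured steps bear on this change: a 55-fold higher number from compound 2 to compound 3 (1.74 log units; beyond the scatter) shows how much the large ester-linked group costs against the small group sitting directly on the ring, and a 2.7-fold lower number from compound 1 to compound 3 (0.43 log units; beyond the scatter) shows that chain length alone shifts the number only modestly. Compound 4 again carries a small group directly on the ring, so a large drop toward compound 2 is expected, a 6.9-fold lower number from compound 3 to compound 4 (0.84 log units; beyond the scatter). Compound 4 is therefore estimated at 80 nM, with a range from 15 nM to 450 nM.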

Compound 4, half-maximal inhibitory concentration: 153 nM
Compound 4: middle estimate off by 1.9-fold (0.28 log units), on the low side; the range from low to high includes it.
By their numbers in this assay, from the lowest: compound 2; then compound 4; then compound 3; then compound 1.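

Trading the ester-linked chain for the small group on this aromatic carbon gives a 3.6-fold lower number from compound 3 to compound 4 (0.56 log units; beyond the scatter) and a 9.7-fold lower number from compound 1 to compound 4 (0.99 log units; beyond the scatter) in this assay, so most of the ground lost to the ester-linked groups is recovered. A small group alone does not settle the matter, however: two small groups on the same carbon still give a 15-fold higher number from compound 2 to compound 4 (1.18 log units; beyond the scatter) in this comparison. Nothing available here explains these gaps. Compound 4 differs from compound 2 both in its nitrile and in the extra carbon before selenium, and the compounds shown do not separate the two. Going by these compounds, how an amine or a carboxylic acid would fare on this carbon also remains open.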